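Pyridazin-3-yl for pyridin-2-yl on compound 2

The compounds below may be only part of what the source reports. "The series", "measured", "known", "first", "only" and "open" are said of these compounds alone.

In an ADME assay on microsomes from liver (Mus musculus) for metabolic stability, with a stated time of 10 min (a lower number here means that less of the compound is left, a higher number that more of the compound is left), compound 2 (`CNC(=O)c1nnc(NC(=O)C2CC2)cc1Nc1cccc(-c2ccccn2)c1OC`) gives 42% and stands lowest of the two numbers, with compound 1 (`CNC(=O)c1nnc(NC(=O)C2CC2)cc1Nc1cccc(-c2cnc(C(C)(C)O)cn2)c1OC`) at 99% on the same read-out. Compound 3 (`CNC(=O)c1nnc(NC(=O)C2CC2)cc1Nc1cccc(-c2cccnn2)c1OC`) carries pyridazin-3-yl in place of pyridin-2-yl on an aromatic carbon. Going by the values given here, one measured step bears on this place: a number 57 percentage points lower from compound 1 to compound 2 (beyond the scatter) when pyridin-2-yl replaces 5-(1-hydroxy-1-methylethyl)pyrazin-2-yl. That exchange is larger than the present one, so only a moderate upward move is expected. The expected step is a number 18 percentage points higher from compound 2 to compound 3 (beyond the scatter) as a working estimate. For compound 3 the estimate is 60% (expected range 40% to 85%).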

Compound 3, percent of the compound remaining: 0%
The estimate for compound 3 lay 60 percentage points above the measured number, and the stated range ends above it.
By their numbers in this assay, from the lowest: compound 3; then compound 2; then compound 1.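

At this aromatic carbon, ortho to a methoxy group, this assay responds strongly to the ring alone: pyridazin-3-yl in place of pyridin-2-yl gives a number 42 percentage points lower from compound 2 to compound 3 (beyond the scatter) with the heavy-atom count unchanged. The read-out therefore follows the ring's hetero atoms and not only the size of the group. The full span at this place, a number 99 percentage points lower from compound 1 to compound 3 (beyond the scatter) on leaving 5-(1-hydroxy-1-methylethyl)pyrazin-2-yl for pyridazin-3-yl, covers the whole range of the three compounds.

Open, from the compounds shown here alone, is whether a 1-hydroxy-1-methylethyl group or an amine on the pyridazin-3-yl ring would restore the number. The available data give no cause for the drop.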